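Swapping Fluoro for Methyl on a Weak Adenosine Ligand

The compounds below may be only part of what the source reports. "The series", "measured", "known", "first", "only" and "open" are said of these compounds alone.

Three compounds with a shared core were tested in an assay on CHO cells for displacement of a labelled ligand from adenosine receptor A3 (Homo sapiens); a higher number here means a weaker inhibitor, a lower number a stronger inhibitor. Compound 1 `CC(C)n1cc2c(C(N)=O)nc(N)nc2n1` reaches only an assay limit, > 100000 nM, which is not a number. Compound 2 `CCOC(=O)c1nc(N)nc2nn(CC(C)(C)C)cc12` gives 10400 nM in this assay. Compound 3 `CCOC(=O)c1nc(NC(=O)c2ccc(F)cc2)nc2nn(C)cc12` also sits at a limit, > 100000 nM, so only an upper bound on its strength is known. It therefore shares the limit of > 100000 nM in this assay, at which 2 of the 3 values shown sit, with compound 1, while compound 2 alone has a measured value.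

Compound 4 `CCOC(=O)c1nc(NC(=O)c2ccc(C)cc2)nc2nn(C)cc12` differs from compound 3 by methyl in place of fluoro on an aromatic carbon, a methyl in place of fluoro on an aromatic carbon. No measured step of this kind exists among these compounds. The change from compound 3 to compound 4 is expected to be a step that the limit leaves unreadable from compound 3 to compound 4, nothing beyond the usual scatter. Compound 4 is estimated at 150000 nM, between 30000 nM and 1000000 nM, and most likely reported again only as a limit.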

Compound 4, inhibition constant: 100000 nM
The estimate for compound 4 lay 1.5-fold (0.18 log units) above the measured number, within the range that was stated.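

In this assay compound 4, with its 4-methylphenyl, gives 100000 nM as an actual number, though a very weak one. Compound 3 rests at > 100000 nM and that is a limit, not a number. The change from 4-fluorophenyl to 4-methylphenyl gives a number no higher from compound 3 to compound 4 (the limit leaves the size open) and its size cannot be read, because one end of the comparison is only a limit: the limit of > 100000 nM in this assay, at which 2 of the 4 values shown sit. As far as these compounds go, what an amine or a carboxylic acid would give in this place stays open, and so does whether either would bring the value clear of the limit.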